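Acylurea thiazole hydrazones: fluorinated benzoyl variants in HeLa cells

This account rests on a few compounds, and the source may have more. Where it says the series, first, only, none or still open, it means among the compounds named here.

Measured so far:
- compound 1, `CN(C(=O)NC(=O)c1ccc(C(F)(F)F)cc1)c1nc(C(F)(F)F)c(C(=O)N/N=C/c2ccc(C(F)(F)F)cc2)s1`, > 100 ug/mL
- compound 2, `CN(C(=O)NC(=O)c1ccccc1F)c1nc(C(F)(F)F)c(C(=O)N/N=C/c2cccc(C(F)(F)F)c2)s1`, 19.1 ug/mL
- compound 3, `CN(C(=O)NC(=O)c1c(F)cccc1F)c1nc(C(F)(F)F)c(C(=O)N/N=C/c2cccc(C(F)(F)F)c2)s1`, 21.6 ug/mL

In a functional assay on HeLa cells (Homo sapiens) for inhibition, read by MTT assay, with a stated time of 72 h (a higher number here means a weaker inhibitor, a lower number a stronger inhibitor), compound 3 gives 21.6 ug/mL, the highest of the two numbers that are not limits. Its nearest neighbour is compound 2, and a 1.1-fold higher number from compound 2 to compound 3 (0.05 log units; within the scatter), so the two are not separable. The value of compound 1 in this assay is a limit, not a number (the limit of > 100 ug/mL in this assay, at which 1 of the 3 values shown sits).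

Compound 4, `CN(C(=O)NC(=O)c1ccc(C(F)(F)F)cc1)c1nc(C(F)(F)F)c(C(=O)N/N=C/c2cccc(C(F)(F)F)c2)s1`, has not been measured. It differs from compound 3 by 4-(trifluoromethyl)phenyl in place of 2,6-difluorophenyl on a carbonyl carbon. Within the data shown here, no measured step covers this exact change. Among the measured compounds shown here, the only step that touches the benzoyl piece, from compound 2 to compound 3, stays within the scatter. Compound 1 carries the same 4-(trifluoromethyl)phenyl on its carbonyl carbon as compound 4, and its value is a limit; compounds 2 and 3, with fluorinated phenyl there, give numbers near each other.

A number higher than that of compound 3 is therefore expected for compound 4, with a fair chance that only a limit is reported. The expected step is a 1.9-fold higher number from compound 3 to compound 4 (0.27 log units; within the scatter). Compound 4 is estimated at 40 ug/mL, between 15 ug/mL and 110 ug/mL.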

Compound 4, half-maximal inhibitory concentration: 6.2 ug/mL
The estimate for compound 4 lay 6.5-fold (0.81 log units) above the measured number, and the stated range ends above it.
By their numbers in this assay, from the lowest: compound 4; then compounds 2 and 3 (each within the scatter of the next). At a limit, above all of these: compound 1.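

On the carbonyl carbon, 4-(trifluoromethyl)phenyl is compatible with a lower number in this assay, with a 3.5-fold lower number from compound 3 to compound 4 (0.54 log units; beyond the scatter) and a 3.1-fold lower number from compound 2 to compound 4 (0.49 log units; beyond the scatter), so this group alone does not account for the result of compound 1. With 4-(trifluoromethyl)phenyl held on the carbonyl carbon, the group on the carbon with a double bond to nitrogen matters, as 3-(trifluoromethyl)phenyl in place of 4-(trifluoromethyl)phenyl there gives an at least 16-fold lower number from compound 1 to compound 4 (1.20 log units; beyond the scatter). That step starts from a limit of compound 1, not a number: the limit of > 100 ug/mL in this assay, at which 1 of the 4 values shown sits.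

On these data alone, whether the benzoyl step depends on the trifluoromethyl group itself or on the loss of the fluoro substituents remains open, since only compound 4 pairs this benzoyl piece with 3-(trifluoromethyl)phenyl. A phenyl carrying a methoxy group or a nitrile on the carbonyl carbon would test how far the step extends.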